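Compound 3 Takes a Naphthalen-1-yl Group in Place of Chlorophenyl

The compounds below may be only part of what the source reports. "The series", "measured", "known", "first", "only" and "open" are said of these compounds alone.

Two compounds have numbers in a functional assay on B16-F10 cells (Mus musculus) for inhibition, read by MTT assay, with a stated time of 48 h; a lower number here means a stronger inhibitor, a higher number a weaker inhibitor. Compound 1 `O=C(/C=C/c1ccc([N+](=O)[O-])cc1)Nc1ccc2ncnc(Nc3cccc(Br)c3)c2c1` gives 0.982 ug/mL in this assay. Compound 2 `O=C(/C=C/c1ccc(Cl)cc1)Nc1ccc2ncnc(Nc3cccc(Cl)c3)c2c1` gives 9.97 ug/mL in this assay, the higher of the two numbers, and its gap to compound 1 lies beyond the usual scatter. Compound 3 `O=C(/C=C/c1cccc2ccccc12)Nc1ccc2ncnc(Nc3cccc(Cl)c3)c2c1` differs from compound 2 by naphthalen-1-yl in place of 4-chlorophenyl on a double-bonded chain carbon bound to a double-bonded chain carbon. Going by the values given here, no measured pair shows this change, so nothing anchors its size. The step of a 1.4-fold lower number from compound 2 to compound 3 (0.15 log units; within the scatter) in this assay is expected to stay within the scatter, with no clear direction. Compound 3 is estimated at 7 ug/mL in this assay, with a range from 2 ug/mL to 25 ug/mL.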

Compound 3, half-maximal inhibitory concentration: 0.671 ug/mL
Beside the measured number, compound 3's estimate is 10-fold (1.02 log units) above it; measured number below the stated range.
By their numbers in this assay, from the lowest: compounds 3 and 1 (each within the scatter of the next); then compound 2.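

In this assay, the step from 4-chlorophenyl to naphthalen-1-yl is a 15-fold lower number from compound 2 to compound 3 (1.17 log units; beyond the scatter). This is the first single change shown, and it makes the group on a double-bonded chain carbon bound to a double-bonded chain carbon a place where one replacement moves the number beyond the scatter; compounds 1 and 2 differ in more than one place and could not show that. Nothing measured here accounts for the step. The compounds shown leave open whether the added ring or the lost chlorine carries it, and how a plain phenyl or a naphthalen-2-yl group would read at this place.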